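Compound 4: a Hydroxyphenyl in Place of the Methoxyphenyl

The compounds below may be only part of what the source reports. "The series", "measured", "known", "first", "only" and "open" are said of these compounds alone.

Measured so far in an assay on mitochondria (strain BALB/c) for inhibition of glycerol-3-phosphate acyltransferase 1, mitochondrial (Mus musculus), read by scintillation counting, with a stated time of 10 min; a lower number here means a stronger inhibitor, a higher number a weaker inhibitor:
compound 1 `CCCCCCCCS(=O)(=O)Nc1ccc(-c2cccc(Cl)c2)cc1C(=O)O`: 8900 nM
compound 2 `CCCCCCCCS(=O)(=O)Nc1ccc(-c2ccc(CCCC)cc2)cc1C(=O)O`: 9000 nM
compound 3 `CCCCCCCCS(=O)(=O)Nc1ccc(-c2ccccc2OC)cc1C(=O)O`: 27600 nM

Compound 3 stands highest of the three in this assay, with compound 1 and compound 2 both well below it. Compound 4 `CCCCCCCCS(=O)(=O)Nc1ccc(-c2ccc(O)cc2)cc1C(=O)O` differs from compound 3 in one place: 4-hydroxyphenyl in place of 2-methoxyphenyl on an aromatic carbon. Among the compounds with values here, two measured steps bear on this change. a 3.1-fold higher number from compound 2 to compound 3 (0.49 log units; beyond the scatter) and a 3.1-fold higher number from compound 1 to compound 3 (0.49 log units; beyond the scatter), each a modest rise beyond the scatter, so a substituent other than 2-methoxy on that ring has twice gone with a lower number. Compound 4 is therefore expected to show a modest drop, a 2.5-fold lower number from compound 3 to compound 4 (0.40 log units; beyond the scatter). The estimate for compound 4 in this assay is 11000 nM, with a range of 4000 nM to 30000 nM.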

Compound 4, half-maximal inhibitory concentration: 47300 nM
Compound 4: the middle estimate sits 4.3-fold (0.63 log units) below what was measured, and the stated range ends below it.
By their numbers in this assay, from the lowest: compounds 1 and 2 (each within the scatter of the next); then compounds 3 and 4 (each within the scatter of the next).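

In this assay, the 4-hydroxyphenyl does not separate from the 2-methoxyphenyl (a 1.7-fold higher number from compound 3 to compound 4 (0.23 log units; within the scatter)), so a replacement for the 2-methoxyphenyl does not by itself bring a lower number. Compound 4 instead stands apart from the butyl and chloro compounds (a 5.3-fold higher number from compound 2 to compound 4 (0.72 log units; beyond the scatter); a 5.3-fold higher number from compound 1 to compound 4 (0.73 log units; beyond the scatter)), which shows that the substituent on this ring matters and that hydroxy does not go with the lower numbers. Nothing given here accounts for this result.

The compounds shown leave open whether an amine or a carboxylic acid in place of the hydroxy would stand with compound 4. They also leave open whether a chain longer than butyl would stand with compound 2.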